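The compounds below may be only part of what the source reports. "The series", "measured", "known", "first", "only" and "open" are said of these compounds alone.

Measured in a functional assay on SNU-638 cells (Homo sapiens) for cytotoxicity, read by MTT assay; a higher number here means a weaker inhibitor, a lower number a stronger inhibitor:
- compound 1 `O=C(/C=C/c1ccc(F)cc1)c1ccc(O)cc1O`: 9430 nM
- compound 2 `COc1cc(O)ccc1C(=O)/C=C/c1ccc(F)cc1`: > 25000 nM (a limit)

Compound 2 gives > 25000 nM, which is a limit of the assay and not a number. The next compound, compound 3 `O=C(/C=C/c1ccc(F)cc1)c1ccc(O)cc1`, carries hydrogen in place of methoxy on an aromatic carbon. Among the measured compounds shown here, no measured step removes this group outright. For the measured compounds named here, the one measured step bears on it only indirectly: an at least 2.6-fold higher number from compound 1 to compound 2 (0.42 log units; beyond the scatter), from methyl in place of hydrogen on an aromatic oxygen. The hydroxy counterpart of compound 2 is compound 1, which gives 9430 nM, and compound 3 is expected to read on the weaker side of that value. The estimated change is modest and towards a lower number, an at least 1.5-fold lower number from compound 2 to compound 3 (0.19 log units; that floor lies within the scatter), though it may not clear the limit. For compound 3 the estimate is 16000 nM, with an expected range of 7000 nM to 35000 nM.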

Compound 3, half-maximal inhibitory concentration: 5540 nM
For compound 3 the middle estimate is 2.9-fold (0.46 log units) above the measured one, and the stated range ends above it.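

In this assay, an at least 4.5-fold lower number from compound 2 to compound 3 (0.65 log units; beyond the scatter) shows that the methoxy on this carbon, ortho to a large group and meta to a hydroxy group, reads as a loss against plain hydrogen, and the shared core needs no oxygen substituent here. The size of that step is only a floor, with compound 2 a limit of the assay and not a number: the limit of > 25000 nM in this assay, at which 1 of the 3 values shown sits. The hydroxy and hydrogen pair gives a 1.7-fold lower number from compound 1 to compound 3 (0.23 log units; within the scatter), so the two cannot be told apart at this carbon, and the earlier methylation step now reads as a cost tied to the methoxy rather than the loss of a needed hydroxy.

Going by these compounds, whether that cost follows the methoxy alone or extends to other substituents, such as an ethoxy or an amine on this carbon, stays open. On these data alone, the contribution of the remaining hydroxy group, common to all three compounds, also stays open.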